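Iodo to Trifluoromethyl: Expected Effect on Cell Growth Inhibition

The compounds below may be only part of what the source reports. "The series", "measured", "known", "first", "only" and "open" are said of these compounds alone.

compound 1 `COc1cc(C(=O)c2sc(-c3ccc(I)cc3)cc2N)cc(OC)c1OC`: 150 nM
compound 2 `COc1cccc(-c2cc(N)c(C(=O)c3cc(OC)c(OC)c(OC)c3)s2)c1`: 16 nM
compound 3 `CCOc1ccc(-c2cc(N)c(C(=O)c3cc(OC)c(OC)c(OC)c3)s2)cc1`: 270 nM

In a functional assay on CCRF-CEM cells (Homo sapiens) for antiproliferative activity (on this read-out lower numbers stand for stronger inhibition and higher numbers for weaker inhibition), compound 1 gives 150 nM, the second highest of the three numbers. The nearest number is reached by a 1.8-fold higher number from compound 1 to compound 3 (0.26 log units; within the scatter), the furthest by a 9.4-fold lower number from compound 1 to compound 2 (0.97 log units; beyond the scatter). Compound 4 `COc1cc(C(=O)c2sc(-c3ccc(C(F)(F)F)cc3)cc2N)cc(OC)c1OC` carries one change relative to compound 1: trifluoromethyl in place of iodo on an aromatic carbon. The step of a 1.8-fold higher number from compound 1 to compound 3 (0.26 log units; within the scatter) bears most closely on it, since it also replaces the same iodo group at the same place and stayed within the scatter. The step of a 9.4-fold lower number from compound 1 to compound 2 (0.97 log units; beyond the scatter) moves the group to another place and is less informative. A step of no more than a 1.1-fold higher number from compound 1 to compound 4 (0.05 log units; within the scatter) is therefore expected. For compound 4 the estimated value is 170 nM, with a range from 60 nM to 500 nM.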

Compound 4, half-maximal inhibitory concentration: 270 nM
For compound 4 the middle estimate is 1.6-fold (0.20 log units) below the measured one; measured number inside the range.
By their numbers in this assay, from the lowest: compound 2; then compounds 1, 3 and 4 (each within the scatter of the next).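

Replacing iodo with trifluoromethyl (a 1.8-fold higher number from compound 1 to compound 4 (0.26 log units; within the scatter)) stays within the scatter, and so does replacing ethoxy with trifluoromethyl (no change at the digits printed from compound 3 to compound 4 (within the scatter)). Iodo, ethoxy and trifluoromethyl at this place therefore cannot be told apart, while compound 2, with its 3-methoxyphenyl, remains clearly separate (a 17-fold higher number from compound 2 to compound 4 (1.23 log units; beyond the scatter)). No measurement here explains this pattern.

On these data alone, whether 4-methoxyphenyl would match compound 2 or these three compounds remains open, so the separate roles of group and place are unresolved. An amine or a carboxylic acid at this place also remains untested among the compounds shown.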